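The source may report more compounds than this note shows. Statements on the series, on what has been measured and on what is new or still open speak of the compounds shown alone.

Of the compounds shown here, two built on a shared core have been tested in a functional assay on P388 cells (Mus musculus) for antiproliferative activity, with a stated time of 72 h; a higher number here means a weaker inhibitor, a lower number a stronger inhibitor. Compound 1, `CSc1cnc2ccccc2c1[Se]CC#CCOC(=O)c1ccc(C(=O)O)cc1`, gives 19.1 ug/mL in this assay. Compound 2, `O=C(/C=C/c1ccccc1)OCC#CCSc1cnc2ccccc2c1Cl`, gives 32.8 ug/mL in this assay. Compound 1 stands at one end of these two numbers, but its gap to compound 2 lies within the scatter, so the two cannot be told apart. For the measured compounds named here, no step between measured compounds that differ in a single place is available here. Compound 3, `CSc1cnc2ccccc2c1[Se]CC#CCOC(=O)c1ccccc1`, has not yet been measured in this assay. It differs from compound 1 in one place: hydrogen in place of carboxy on an aromatic carbon. The rest of the shared core of compound 1 is untouched. Going by the values given here, nothing among the measured compounds shows how such a change acts, so compound 3 is expected to come out close to compound 1, with the step of a 1.2-fold lower number from compound 1 to compound 3 (0.08 log units; within the scatter) estimated to fall within the scatter and in no firm direction. Compound 3 is therefore estimated at 16 ug/mL, between 6 ug/mL and 40 ug/mL.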

Compound 3, concentration for 50% inhibition: 3.5 ug/mL
For compound 3 the middle estimate is 4.6-fold (0.66 log units) above the measured one; the measured number lies below the stated range.
By their numbers in this assay, from the lowest: compound 3; then compounds 1 and 2 (each within the scatter of the next).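

In this assay, for the compounds shown here, the change from 4-carboxyphenyl to phenyl gives a 5.5-fold lower number from compound 1 to compound 3 (0.74 log units; beyond the scatter) and so supplies the first step in this set that differs in a single place. It shows that this position on the aromatic ring, para to a large group, bears on the read-out, and that hydrogen in place of carboxy goes with a stronger inhibitor here. No measured property is available to account for the size or direction of this step.

Going by these compounds, whether another group at this place, such as an amine, a methoxy group or a methyl ester, would keep the lower number or return it towards that of the carboxy compound remains open. The step also rests on one pair, so how far it holds elsewhere on the shared core is not settled.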